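The compounds below may be only part of what the source reports. "The series", "measured", "known", "first", "only" and "open" are said of these compounds alone.

Measured so far in an ADME assay on L6 cells (Rattus norvegicus) for cytotoxicity; a lower number here means a stronger inhibitor, a higher number a weaker inhibitor:
compound 1 `O=C(CCN1CCCCC1)N1CCC2(N3CCCCC3)CC(c3ccccc3)C1C(c1ccccc1)C2` — 63900 nM
compound 2 `CCN1CCN(CCN2CCC3(N4CCCCC4)CC(c4ccccc4)C2C(c2ccccc2)C3)CC1` — 67500 nM
compound 3 `CN(C)C12CCN(C(=O)CCN3CCCCC3)C(C(c3ccccc3)C1)C(c1ccccc1)C2` — 128000 nM

Compound 4 `CCN1CCN(CCN2CCC3(N(C)C)CC(c4ccccc4)C2C(c2ccccc2)C3)CC1` is not yet measured. Its structure stands to compound 3 as compound 2 stands to compound 1: the change from compound 3 to compound 4 is 2-(4-ethylpiperazin-1-yl)ethyl in place of (2-(piperidin-1-yl)ethyl)carbonyl on an amine nitrogen in a ring, and the change from compound 1 to compound 2 is 2-(4-ethylpiperazin-1-yl)ethyl in place of (2-(piperidin-1-yl)ethyl)carbonyl on an amine nitrogen in a ring. That change has been made once with a measured outcome, giving a 1.1-fold higher number from compound 1 to compound 2 (0.02 log units; within the scatter). Around the place, the two cases are not identical: in compound 1 the ring nitrogen that carries the change is three ring bonds from the ring atom that bears a piperidin-1-yl group, whereas in compound 3 it is three ring bonds from the ring atom that bears a dimethylamino group. The change from compound 3 to compound 4 is therefore the same kind of change as that from compound 1 to compound 2, not the same change.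

The two cores differ as dimethylamino in place of piperidin-1-yl on a saturated ring carbon, which gave a 2.0-fold higher number from compound 1 to compound 3 (0.30 log units; within the scatter). All three measured values lie within the scatter of one another, so no order among compounds 1, 2 and 3 can be stated.

For compound 4 the step is expected to be about a 1.1-fold higher number from compound 3 to compound 4 (0.04 log units; within the scatter), in line with the earlier step, because the same kind of change gave a 1.1-fold higher number from compound 1 to compound 2 (0.02 log units; within the scatter) in compound 1 to compound 2. For the measured compounds named here, on that basis compound 4 is estimated at 140000 nM in this assay, with a range from 70000 nM to 280000 nM; the single precedent and the high value of compound 3 leave room for a limit rather than a number.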

Compound 4, half-maximal inhibitory concentration: 58000 nM
Estimate against measurement, compound 4: 2.4-fold (0.38 log units) above, outside the stated range (below it).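

In this assay, 2-(4-ethylpiperazin-1-yl)ethyl in place of (2-(piperidin-1-yl)ethyl)carbonyl gives a 2.2-fold lower number from compound 3 to compound 4 (0.34 log units; beyond the scatter), a modest step, and set beside the earlier step on the other core it does not differ beyond what scatter allows: the same change on two cores in this assay, a 1.1-fold higher number (0.02 log units; within the scatter) from compound 1 to compound 2 and a 2.2-fold lower number (0.34 log units; beyond the scatter) from compound 3 to compound 4, 2.3-fold (0.37 log units) apart, within the scatter of two such steps

Read the other way round, dimethylamino in place of piperidin-1-yl on a saturated ring carbon gives a 1.2-fold lower number from compound 2 to compound 4 (0.07 log units; within the scatter), and this step likewise cannot be told apart from its earlier counterpart: the same change on two cores in this assay, a 2.0-fold higher number (0.30 log units; within the scatter) from compound 1 to compound 3 and a 1.2-fold lower number (0.07 log units; within the scatter) from compound 2 to compound 4, 2.3-fold (0.37 log units) apart, within the scatter of two such steps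

The two pairs therefore give no sign that either change depends on the core, but they do not show that either carries over unchanged, since each comparison rests on a single pair of steps and a real difference of this size could not be separated from scatter.

The compounds shown leave open whether the exchange on the ring nitrogen behaves the same way with a morpholin-4-yl group or a primary amine on the saturated ring carbon. They also leave open what a longer chain between the ring nitrogen and the 4-ethylpiperazin-1-yl ring would do in this assay.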